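Swapping the Carbonyl Group for a Sulfonyl Group

The source may report more compounds than this note shows. Statements on the series, on what has been measured and on what is new or still open speak of the compounds shown alone.

- Compound 1 `O=C(Nc1ccc(O)c2c(=O)cc(-c3ccccc3Cl)oc12)c1ccc(Cl)c(Cl)c1` gives 13000 nM
- Compound 2 `O=c1cc(-c2ccccc2Cl)oc2c(N3CCCCC3)ccc(O)c12` gives 5700 nM

Both numbers come from a functional assay on ID8 cells (Mus musculus) for antiproliferative activity (on this read-out higher numbers stand for weaker inhibition and lower numbers for stronger inhibition), and they lie apart by more than the usual scatter of repeated measurements. Compound 1 has the higher number of the two, so it is the weaker inhibitor of this pair.

The next compound to be tested is compound 3 `O=c1cc(-c2ccccc2Cl)oc2c(NS(=O)(=O)c3ccccc3)ccc(O)c12`, which keeps the core of compound 1 and changes one group. The change phenylsulfonyl in place of (3,4-dichlorophenyl)carbonyl on a nitrogen on an aromatic ring puts phenylsulfonyl in place of (3,4-dichlorophenyl)carbonyl on a nitrogen on an aromatic ring. Both groups hold one six-membered aromatic ring of carbon only.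

Among the compounds with values here, no measured pair tests this swap directly. Within the data shown here, the only guide is that compound 2 at 5700 nM carries a different group on the shared core and remains only modestly apart from compound 1. In this assay no change beyond the scatter is therefore expected, and the expected step of a 1.6-fold lower number from compound 1 to compound 3 (0.21 log units; within the scatter) is small. For compound 3 the estimated value is 8000 nM (expected range 2500 nM to 25000 nM).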

Compound 3, half-maximal inhibitory concentration: 9500 nM
Beside the measured number, compound 3's estimate is 1.2-fold (0.07 log units) below it, within the range that was stated.
By their numbers in this assay, from the lowest: compounds 2, 3 and 1 (each within the scatter of the next, the first and the last beyond it).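

Measured in this assay the exchange of (3,4-dichlorophenyl)carbonyl for phenylsulfonyl on a nitrogen on an aromatic ring gives a 1.4-fold lower number from compound 1 to compound 3 (0.14 log units; within the scatter) and so leaves compound 1 and compound 3 indistinguishable on this read-out. This position therefore accepts a sulfonyl link in place of a carbonyl link, with the aromatic ring kept and the chlorine atoms gone, and the number stays within the scatter. No measurement shown here offers an explanation for this result.

This one swap changes both the link and the ring's substituents. The outcome cannot be split between them, and the two changes might have no effect or might offset each other. Phenylcarbonyl and (3,4-dichlorophenyl)sulfonyl on the same nitrogen would separate those two changes, while methylsulfonyl would leave open whether the aromatic ring on the sulfonyl is needed at all.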